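The compounds below may be only part of what the source reports. "The series", "measured", "known", "first", "only" and "open" are said of these compounds alone.

In a functional assay on HCT-116 cells (Homo sapiens) for cytotoxicity, read by fluorescence, with a stated time of 72 h (a lower number here means a stronger inhibitor, a higher number a weaker inhibitor), three compounds have been measured:

Compound 1 `CC(C)c1n[nH]c2c(NCc3ccc(-c4ccccn4)cc3)nc(NCCO)nc12`: 27 nM
Compound 2 `CC(C)c1n[nH]c2c(NCc3ccc(-c4ccccn4)cc3)nc(N3CCCCC3CCO)nc12`: 142 nM
Compound 3 `CC(C)c1n[nH]c2c(NCc3ccc(-c4ccccn4)cc3)nc(NCC(N)CO)nc12`: 781 nM

Compound 2 holds the middle place among these three numbers, with compound 1 lower and compound 3 higher. Compound 4 `CC(C)c1n[nH]c2c(NCc3ccc(-c4ccccn4)cc3)nc(N3CCNCC3)nc12` has not yet been measured. It differs from compound 2 in one place, with piperazin-1-yl in place of 2-(2-hydroxyethyl)piperidin-1-yl on an aromatic carbon.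

Among the measured compounds shown here, two measured steps bear on this change. Putting the 2-(2-hydroxyethyl)piperidin-1-yl group in place of (2-hydroxyethyl)amino gave a 5.3-fold higher number from compound 1 to compound 2 (0.72 log units; beyond the scatter), and replacing it with an open chain gave a 5.5-fold higher number from compound 2 to compound 3 (0.74 log units; beyond the scatter). Both steps are modest and beyond the scatter, but neither involves piperazin-1-yl, so they only loosely limit the outcome. A small to modest step is therefore expected in this assay, leaning towards a higher number. The expected step is a 1.4-fold higher number from compound 2 to compound 4 (0.15 log units; within the scatter). For compound 4 the estimated value is 200 nM, with an expected range from 50 nM to 800 nM.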

Compound 4, half-maximal inhibitory concentration: 88 nM
Estimate against measurement, compound 4: 2.3-fold (0.36 log units) above, within the range that was stated.
By their numbers in this assay, from the lowest: compound 1; then compounds 4 and 2 (each within the scatter of the next); then compound 3.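

In this assay, a ring with no oxygen can stand on this carbon between two ring nitrogen atoms: piperazin-1-yl replaces 2-(2-hydroxyethyl)piperidin-1-yl with a 1.6-fold lower number from compound 2 to compound 4 (0.21 log units; within the scatter) and so stays level with the larger group. The ring also reads far better than the open chain of the same heavy-atom count, with an 8.9-fold lower number from compound 3 to compound 4 (0.95 log units; beyond the scatter) as the step. Yet piperazin-1-yl does not match the small (2-hydroxyethyl)amino group, as a 3.3-fold higher number from compound 1 to compound 4 (0.51 log units; beyond the scatter) shows. Nothing available here accounts for these differences.

Still open, going by these compounds, is how a morpholin-4-yl ring, which would put an oxygen in place of the free ring nitrogen, would read in this assay at this carbon. Also open, on these data alone, is what a methyl or a 2-hydroxyethyl group on that free piperazine nitrogen would do.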